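The source may hold more compounds than are shown below. What is called first, only, known or untested is meant among the compounds shown, and "the series" means these compounds.

Working notes on the series around compound 2 `CC(=O)Nc1cc(Nc2cc(NC3CC3)n3ncc(C#N)c3n2)ccc1N1CC[C@H](N(C)C)C1`. In an ADME assay on cells (Hepatocyte, Rattus norvegicus) for metabolic stability (a higher number here means faster removal of the compound, a lower number slower removal), compound 2 gives 2.5 uL/min, the lowest of the two numbers shown. Compound 3 `CC(=O)Nc1cc(Nc2cc(NC3CC3)n3ncc(C#N)c3n2)ccc1NCCCO` gives 17 uL/min in this assay, the step being a 6.8-fold higher number from compound 2 to compound 3 (0.83 log units; beyond the scatter). Compound 1 `CC(=O)Nc1cc(Nc2cc(NC3CC3)n3ncc(C#N)c3n2)ccc1N1CCC[C@@H](N)C1` sits at a limit of this assay, < 1 uL/min, (the limit of < 1 uL/min in this assay, at which 1 of the 3 values shown sits). Compound 4 `CC(=O)Nc1cc(Nc2cc(NC3CC3)n3ncc(C#N)c3n2)ccc1N1CC[C@H](N)C1` has not yet been measured; it differs from compound 2 by amino in place of dimethylamino on a saturated ring carbon. Within the data shown here, the one measured step that bears on this, an at least 2.5-fold higher number from compound 1 to compound 2 (0.39 log units; beyond the scatter), ran upward while also exchanging the ring, so a move back toward the limit of compound 1 is expected, though a smaller one. Compound 4 is therefore expected in this assay at 1.2 uL/min, range 0.5 uL/min to 3 uL/min, a step of a 2.1-fold lower number from compound 2 to compound 4 (0.32 log units; beyond the scatter).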

Compound 4, intrinsic clearance in a liver preparation (reported as CLH), per the amount of preparation that the assay uses: < 1 uL/min
Compound 4: a limit, no number; the forecaster's own chance of this, stated with the estimate: 40%; at least 1.2-fold (0.07 log units) between middle value and limit.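

With the ring held constant, amino in place of dimethylamino on the saturated ring carbon alone moves this assay, giving an at least 2.5-fold lower number from compound 2 to compound 4 (0.39 log units; beyond the scatter), a change that the earlier step, which also exchanged the ring, could not separate. Against the open chain, 3-aminopyrrolidin-1-yl in place of (3-hydroxypropyl)amino gives an at least 17-fold lower number from compound 3 to compound 4 (1.23 log units; beyond the scatter). The value of compound 4 is a limit, not a number: the limit of < 1 uL/min in this assay, at which 2 of the 4 values shown sit.

From the compounds shown here alone, the step between the two limits cannot be read, so any effect of ring size between 3-aminopiperidin-1-yl and 3-aminopyrrolidin-1-yl stays open. Also open, going by these compounds, is where methylamino, the intermediate amine at this ring carbon, would fall.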